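Chloro in Place of Methoxy on the Shared Core

The compounds below may be only part of what the source reports. "The series", "measured", "known", "first", "only" and "open" are said of these compounds alone.

Compound 2 `COc1ccccc1N1CCN(CCn2nc(-n3ccnc3)ccc2=O)CC1` carries a methoxy group and, in an assay on cell membranes from brain for binding affinity to Adrenergic receptor alpha-1 (Rattus norvegicus), read by radioligand binding (a higher number here means a weaker inhibitor, a lower number a stronger inhibitor), compound 2 gives 237 nM, the higher of the two numbers recorded so far. Compound 1 `O=c1ccc(-n2cnc3ccccc32)nn1CCN1CCN(c2ccccc2Cl)CC1` differs from it in two places and gives 70.4 nM in this assay. Compound 3 `O=c1ccc(-n2ccnc2)nn1CCN1CCN(c2ccccc2Cl)CC1` arises from compound 2 by chloro in place of methoxy on an aromatic carbon, turning 2-methoxyphenyl into 2-chlorophenyl. Among the measured compounds shown here, no single-change step has been measured here. Since compound 1, which also bears the chloro group, shows 70.4 nM, compound 3 is expected to bind somewhat more tightly, with a step of a 2.0-fold lower number from compound 2 to compound 3 (0.30 log units; within the scatter) toward a lower number. Compound 3 is estimated at 120 nM, between 45 nM and 320 nM.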

Compound 3, inhibition constant: 472 nM
For compound 3 the middle estimate is 3.9-fold (0.59 log units) below the measured one; the whole stated range lies below it.
By their numbers in this assay, from the lowest: compound 1; then compounds 2 and 3 (each within the scatter of the next).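

In this assay, the step at this position, ortho to a large group, reads a 2.0-fold higher number from compound 2 to compound 3 (0.30 log units; within the scatter), so with 1H-imidazol-1-yl in place this swap is not separated from the scatter. The step beyond the scatter lies at the other place, where 1H-imidazol-1-yl in place of 1H-benzimidazol-1-yl with chloro held fixed reads a 6.7-fold higher number from compound 1 to compound 3 (0.83 log units; beyond the scatter). Nothing shown accounts for either step.

Going by these compounds, whether methoxy on the 1H-benzimidazol-1-yl compound would read like chloro stays open, as does the outcome of a fluoro or methyl group on the same aromatic carbon.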